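Aryl exchange on the core of compound 1

This account rests on a few compounds, and the source may have more. Where it says the series, first, only, none or still open, it means among the compounds named here.

Compound 1 `C=CCn1c(=O)/c(=C\c2cccc(Cl)c2)[nH]c(=O)/c1=C\c1ccccc1OC` gives 8900 nM in a functional assay on Huh-7 cells (Homo sapiens) for cytotoxicity, read by CCK-8 assay, with a stated time of 72 h (a lower number here means a stronger inhibitor, a higher number a weaker inhibitor), the highest of the two numbers in hand. Compound 2 `C=CCn1c(=O)/c(=C\c2cc(F)ccc2C)[nH]c(=O)/c1=C\c1ccccc1OC` gives 5600 nM in this assay; the step of a 1.6-fold lower number from compound 1 to compound 2 (0.20 log units; within the scatter) lies within the scatter. Compound 3 `COc1ccccc1/C=c1/[nH]c(=O)/c(=C\c2ccccc2OC)[nH]c1=O` was reported as "not active" (no number reported) in this assay, with no number given. Compound 4 `C=CCn1c(=O)/c(=C\c2ccccc2F)[nH]c(=O)/c1=C\c1ccccc1OC` is still to be measured in this assay. It differs from compound 1 as follows: 2-fluorophenyl in place of 3-chlorophenyl on a double-bonded chain carbon bound to an aromatic carbon. Among the compounds with values here, the only measured step that bears on this change, a 1.6-fold lower number from compound 1 to compound 2 (0.20 log units; within the scatter), exchanged the same group at the same place and stayed within the scatter, so no movement beyond the scatter is expected here in either direction. The value of compound 4 in this assay is estimated at 8000 nM, within 3000 nM to 25000 nM. The step of a 1.1-fold lower number from compound 1 to compound 4 (0.05 log units; within the scatter) is thus expected to remain within the scatter.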

Compound 4, half-maximal inhibitory concentration: 31300 nM
The estimate for compound 4 lay 3.9-fold (0.59 log units) below the measured number; measured number above the stated range.
By their numbers in this assay, from the lowest: compounds 2 and 1 (each within the scatter of the next); then compound 4.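

In this assay, the aryl group on a double-bonded chain carbon bound to an aromatic carbon proves sensitive to exchange: 2-fluorophenyl gives a 3.5-fold higher number from compound 1 to compound 4 (0.55 log units; beyond the scatter) and a 5.6-fold higher number from compound 2 to compound 4 (0.75 log units; beyond the scatter), both beyond the scatter, whereas the earlier exchange stayed within it. Compound 4 therefore stands apart, with the highest number of the three measured compounds. No available measurement accounts for this shift.

The compounds shown do not separate the change of halogen from the change in its place on the phenyl group. Going by these compounds, how an amine or a carboxylic acid on that phenyl group would read also remains open.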